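Halogen swap on the phenyl analogue of a mercaptoacrylic acid series

A few compounds are considered here, and "the series" means these few. Any claim that something is new, unique, unknown or untested is made for them only; others in the source may bear on it.

Of the compounds shown here, three sharing the mercaptoacrylic acid core have been measured in an assay on isolated protein for inhibition of Calpain-1 catalytic subunit (Sus scrofa); a lower number here means a stronger inhibitor, a higher number a weaker inhibitor. Compound 1 `O=C(O)/C(S)=C/c1c[nH]c2ccc(F)cc12` gives 930 nM, and compound 2 `O=C(O)/C(S)=C/c1c[nH]c2c(I)cccc12` gives 220 nM. Compound 3 `O=C(O)/C(S)=C/c1cccc(Br)c1` gives 8400 nM, the highest of the three numbers: compound 1 sits a good way lower, and compound 2 lower still, both gaps beyond the usual scatter, so compound 3 is the weakest inhibitor of the set in this assay.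

Compound 4 `O=C(O)/C(S)=C/c1cccc(Cl)c1` is not yet measured. It differs from compound 3 by chloro in place of bromo on an aromatic carbon. Among the compounds with values here, no step between measured compounds speaks to this kind of change, and the other two compounds carry a different core, so no direct guide exists. One halogen replacing another at the same carbon is expected to move the number little, and any shift is expected to stay within, or only just beyond, the scatter; the step of a 1.2-fold higher number from compound 3 to compound 4 (0.08 log units; within the scatter) is the estimated change. Compound 4 is therefore expected to give about 10000 nM in this assay, with a range from 4000 nM to 25000 nM.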

Compound 4, half-maximal inhibitory concentration: 13100 nM
Compound 4: the middle estimate sits 1.3-fold (0.12 log units) below what was measured, and the stated range covers the measured number.
By their numbers in this assay, from the lowest: compound 2; then compound 1; then compounds 3 and 4 (each within the scatter of the next).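

In this assay, within the data shown here, chloro in place of bromo on an aromatic carbon gives a 1.6-fold higher number from compound 3 to compound 4 (0.19 log units; within the scatter) and is the first step in the set that isolates a single change, so the two halogens cannot be told apart at this carbon. Compound 3 and compound 4 therefore read as one level of inhibition, and this pair says nothing about the core of compound 1 or compound 2. No measured evidence accompanies this result.

Going by these compounds, whether this level holds for a group of another kind at the same carbon, such as an amine, a methoxy group or a carboxylic acid, stays open. Also open, on these data alone, is whether one halogen replacing another on the core of compound 1 or compound 2 would likewise stay within the scatter.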